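A Chloropropyl Chain in Place of a Methoxyphenyl Group

This account rests on a few compounds, and the source may have more. Where it says the series, first, only, none or still open, it means among the compounds named here.

Compound 1 `CC(C)(C)OC(=O)N1CCN(C(=S)SCc2cn(C[C@H](O)[C@H]3OC(=O)C(OCc4ccccc4)=C3OCc3ccccc3)nn2)CC1`: > 100000 nM
Compound 2 `COc1ccccc1-c1cn(C[C@H](O)[C@H]2OC(=O)C(OCc3ccccc3)=C2OCc2ccccc2)nn1`: > 100000 nM

Of the compounds shown here, two sharing the same core have been tested in a functional assay on HepG2 cells (Homo sapiens) for antiproliferative activity, read by MTT assay, with a stated time of 72 h; on this read-out higher numbers stand for weaker inhibition and lower numbers for stronger inhibition. In this assay compound 1 gives > 100000 nM, which is a limit of the assay and not a number. Compound 2 likewise gives > 100000 nM in this assay, again only a limit. Compound 2 therefore stands at the same limit as compound 1, and nothing separates the two: the limit of > 100000 nM in this assay, at which 2 of the 2 values shown sit.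

Compound 3 `O=C1O[C@H]([C@@H](O)Cn2cc(CCCCl)nn2)C(OCc2ccccc2)=C1OCc1ccccc1` is not yet measured. It differs from compound 2 in a single place, (3-chloropropyl in place of 2-methoxyphenyl on an aromatic carbon). Going by the values given here, no step between measured compounds is available here, so there is no measured change on which to rest a direction. With both measured values sitting at the limit, the step from compound 2 to compound 3 is expected to be a step that the limit leaves unreadable from compound 2 to compound 3, that is, no movement beyond the scatter. Compound 3 is therefore estimated at 150000 nM, within a range of 40000 nM to 500000 nM, and most likely to be reported again only as a limit.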

Compound 3, half-maximal inhibitory concentration: 35000 nM
Compound 3: middle estimate off by 4.3-fold (0.63 log units), on the high side; measured number below the stated range.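

Putting 3-chloropropyl in place of 2-methoxyphenyl on this aromatic carbon of the five-membered ring gives the first readable difference among these compounds in this assay: an at least 2.8-fold lower number from compound 2 to compound 3 (0.45 log units; beyond the scatter). From the compounds shown here alone, one end of this step is a limit of the assay and not a number, so the step gives only a minimum size, and how far the change really reaches remains unknown. The earlier compounds could show no such thing, and compound 3 is the only one shown to leave the limit: the limit of > 100000 nM in this assay, at which 2 of the 3 values shown sit.

The change removes the aromatic ring and its methoxy oxygen and brings in an open chain and a chlorine all at once, so the compounds shown do not say which of these matters; a plain propyl chain or an unsubstituted phenyl ring at the same position would begin to separate them. They also leave open whether a longer chlorinated chain, or an amine or a hydroxyl group at the end of the chain, would carry the number in this assay further down or back to the limit.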